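This account rests on a few compounds, and the source may have more. Where it says the series, first, only, none or still open, it means among the compounds named here.

Measured compounds:
compound 1, `CC(=O)CCSC(=S)NCc1cccnc1`, 4220 nM
compound 2, `OCCCSC(=S)NCc1cccnc1`, 6610 nM
compound 3, `CCCCOC(=O)CCSC(=S)NCc1cccnc1`, 12800 nM

In a functional assay on MDA-MB-468 cells (Homo sapiens) for cytotoxicity, read by resazurin assay, with a stated time of 72 h (a lower number here means a stronger inhibitor, a higher number a weaker inhibitor), compound 3 gives the highest of the three numbers. Its step to compound 2 lies within the scatter, while the step of a 3.0-fold higher number from compound 1 to compound 3 (0.48 log units; beyond the scatter) is the one clear difference in the set. The step of a 1.6-fold higher number from compound 1 to compound 2 (0.19 log units; within the scatter) stays within the scatter.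

Compound 4, `NC(=O)CCSC(=S)NCc1cccnc1`, differs from compound 3 in one place: amino in place of butoxy on a carbonyl carbon. The step that bears most directly on this change is a 3.0-fold higher number from compound 1 to compound 3 (0.48 log units; beyond the scatter), since it also alters the group on the carbonyl carbon, and it shows that the butoxy group carried the weakest result of the series. Among the compounds with values here, no measured step tells what an amino group on that carbonyl carbon does; the closest hint is compound 2, whose hydroxymethyl group, a hydrogen-bond donor, gives a number within the scatter of compound 1. Removing the butoxy is therefore expected to bring compound 4 back toward the numbers of compounds 1 and 2, an expected step of a 2.1-fold lower number from compound 3 to compound 4 (0.33 log units; beyond the scatter) in this assay. Compound 4 is estimated at 6000 nM, with a range of 2500 nM to 15000 nM.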

Compound 4, half-maximal inhibitory concentration: 4630 nM
Estimate against measurement, compound 4: 1.3-fold (0.11 log units) above; low and high end bracket the measured number.
By their numbers in this assay, from the lowest: compounds 1, 4, 2 and 3 (each within the scatter of the next, the first and the last beyond it).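

In this assay, amino in place of butoxy on the carbonyl carbon gives a 2.8-fold lower number from compound 3 to compound 4 (0.44 log units; beyond the scatter) and so separates the two groups clearly, which shows that this carbonyl carbon does not respond to every replacement alike. Amino and methyl on that carbon cannot be told apart, with a 1.1-fold higher number from compound 1 to compound 4 (0.04 log units; within the scatter) as their step, and the carbamoyl and hydroxymethyl groups on the saturated chain carbon also cannot be told apart, with a 1.4-fold lower number from compound 2 to compound 4 (0.15 log units; within the scatter) as their step, so compound 3 alone stands out, although it remains within the scatter of compound 2. No supporting measurement accounts for these results.

The compounds shown leave open whether a methoxy group on the carbonyl carbon would read like butoxy or like amino. They also leave open how a carboxylic acid or a methylamino group would read there.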